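A few compounds are considered here, and "the series" means these few. Any claim that something is new, unique, unknown or untested is made for them only; others in the source may bear on it.

Measured so far:
- compound 1 `O=C1C(=O)N(Cc2ccc(-c3cccnc3)cn2)c2ccc(OC(F)(F)F)cc21`: "not determined" (no result reported)
- compound 2 `O=C1C(=O)N(Cc2ccc(-c3ccccc3)cn2)c2ccc(OC(F)(F)F)cc21`: 47%
- compound 3 `O=C1C(=O)N(Cc2ccc(Oc3nccs3)cc2)c2ccc(OC(F)(F)F)cc21`: 58%

In a functional assay on CHO cells for positive allosteric modulation of muscarinic acetylcholine receptor M5 (Homo sapiens), read by FLIPR and calcium flux, with a stated time of 1 h (a higher number here means a larger maximal response, a lower number a smaller maximal response), compound 1 gave no number. Compound 2 gives 47% in this assay. Compound 3 gives 58% in this assay, the higher of the two available numbers, and its gap to compound 2 lies beyond the usual scatter. Compound 4 `O=C1C(=O)N(Cc2ccc(Oc3cccc(F)n3)cc2)c2ccc(OC(F)(F)F)cc21` differs from compound 3 in one place: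

6-fluoropyridin-2-yl in place of 1,3-thiazol-2-yl on an oxygen on an aromatic ring

Among the compounds with values here, no two measured compounds differ by a single change of this kind, so there is no measured step to lean on; the two known numbers come from compounds that differ in more than one place. The step expected here, a number 3 percentage points lower from compound 3 to compound 4 (within the scatter), is none beyond the scatter. Compound 4 is therefore expected to give 55% in this assay, within a range from 40% to 70%.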

Compound 4, largest response reached (Emax), in percent of the reference or control that the assay uses: 62%
Compound 4: the middle estimate sits 7 percentage points below what was measured, and the stated range covers the measured number.
By their numbers in this assay, from the lowest: compound 2; then compounds 3 and 4 (each within the scatter of the next).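

In this assay, putting 6-fluoropyridin-2-yl in place of 1,3-thiazol-2-yl gives a number 4 percentage points higher from compound 3 to compound 4 (within the scatter) and so leaves the maximal response level. On this oxygen, then, a six-membered aromatic ring carrying a fluorine serves as well as a five-membered aromatic ring containing sulfur. No measurement here explains this match. Still open, from the compounds shown here alone, is what the fluorine contributes, which a plain pyridin-2-yl group or a chlorine in its place would test. Also open, going by these compounds, is how a non-aromatic group, such as an amine or a longer carbon chain, would behave on that oxygen.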